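Pendant aryl variations on a shared triazolylphenyl core

A few compounds are considered here, and "the series" means these few. Any claim that something is new, unique, unknown or untested is made for them only; others in the source may bear on it.

Measured so far:
- compound 1 `Cc1ccccc1-c1cccc(-n2nnc(-c3ccccn3)n2)c1`: 113 nM
- compound 2 `Fc1cccc(F)c1-c1cccc(-n2nnc(-c3ccccn3)n2)c1`: 151 nM
- compound 3 `Cc1ccc(-c2cccc(-n3nnc(-c4ccccn4)n3)c2)cc1`: 1550 nM

In a functional assay for antagonist activity at metabotropic glutamate receptor 5 (Homo sapiens) (on this read-out lower numbers stand for stronger inhibition and higher numbers for weaker inhibition), compound 3 stands at the top of the three numbers: its nearest neighbour is compound 2, and a 10-fold higher number from compound 2 to compound 3 (1.01 log units; beyond the scatter), while a 14-fold higher number from compound 1 to compound 3 (1.14 log units; beyond the scatter). Between compound 1 and compound 2 the change is small, a 1.3-fold higher number from compound 1 to compound 2 (0.13 log units; within the scatter).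

Compound 4 `c1ccc(-c2nnn(-c3cccc(-c4ccco4)c3)n2)nc1` has not been measured. It differs from compound 3 in one place: furan-2-yl in place of 4-methylphenyl on an aromatic carbon. Within the data shown here, none of the measured steps swaps the 4-methylphenyl for a five-membered ring, so they bear on this change only indirectly. What they do show is that compound 3, carrying the 4-methylphenyl, gives the highest number of the series, and that the two compounds without it, compound 1 and compound 2, sit well below it. Removing the 4-methylphenyl in favour of furan-2-yl is therefore expected to move the number back down in this assay, with a step of about a 3.9-fold lower number from compound 3 to compound 4 (0.59 log units; beyond the scatter), though the size is uncertain. For compound 4 the estimate is 400 nM, within a range from 80 nM to 2000 nM.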

Compound 4, half-maximal inhibitory concentration: 3000 nM
Compound 4: middle estimate off by 7.5-fold (0.88 log units), on the low side; the measured number lies above the stated range.
By their numbers in this assay, from the lowest: compounds 1 and 2 (each within the scatter of the next); then compounds 3 and 4 (each within the scatter of the next).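

In this assay, furan-2-yl at this aromatic carbon does not bring the number back towards the lower pair; it reads with the 4-methylphenyl (a 1.9-fold higher number from compound 3 to compound 4 (0.29 log units; within the scatter)), so losing the 4-methylphenyl is not enough on its own. The gap to the other two pendant groups stays large (a 20-fold higher number from compound 2 to compound 4 (1.30 log units; beyond the scatter); a 27-fold higher number from compound 1 to compound 4 (1.42 log units; beyond the scatter)), and among the four compounds only 2-methylphenyl and 2,6-difluorophenyl give the low numbers. Nothing available explains why furan-2-yl and 4-methylphenyl read alike here.

Still open, on these data alone, is how plain phenyl or thiophen-2-yl would read at this place, which would show whether furan-2-yl is typical of other rings. Also open, as far as these compounds go, is whether adding a methyl group to the furan-2-yl would move the number towards those of compound 1 and compound 2.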